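The source may hold more compounds than are shown below. What is called first, only, known or untested is meant among the compounds shown, and "the series" means these compounds.

Measured so far in a functional assay on M14 cells (Homo sapiens) for inhibition, read by sulforhodamine B assay, with a stated time of 48 h; on this read-out lower numbers stand for stronger inhibition of growth and higher numbers for weaker inhibition of growth:
- compound 1, `Nc1cc(N)c2nc(-c3ccccc3)c(NCc3ccc(Cl)c(Cl)c3)nc2c1`, gives 34700 nM
- compound 2, `COc1ccc(CNc2nc3cc(N)cc(N)c3nc2-c2ccccc2)cc1OC`, gives 7760 nM
- compound 3, `Nc1cc(N)c2nc(-c3ccccc3)c(NCc3ccc(F)cc3)nc2c1`, gives 56200 nM

Compound 3 has the highest of the three numbers. Its gap to compound 1 is within the scatter, so the two cannot be told apart, while the step of a 7.2-fold higher number from compound 2 to compound 3 (0.86 log units; beyond the scatter) lies beyond it.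

Compound 4, `COc1ccc(CNc2nc3cc(N)cc(N)c3nc2-c2ccccc2)cc1`, is not yet measured. It differs from compound 3 in one place: methoxy in place of fluoro on an aromatic carbon.

Two measured steps speak to this change. The step of a 7.2-fold higher number from compound 2 to compound 3 (0.86 log units; beyond the scatter) ran in the opposite direction, replacing two methoxy groups with a single fluoro. The step of a 4.5-fold lower number from compound 1 to compound 2 (0.65 log units; beyond the scatter) also brought in the 3,4-dimethoxyphenyl group, there in place of 3,4-dichlorophenyl. Compound 4 carries only one methoxy, so a move back toward compound 2 is expected, though perhaps not all the way. A lower number in this assay is therefore expected for compound 4, of about a 2.8-fold lower number from compound 3 to compound 4 (0.45 log units; beyond the scatter). The estimate for compound 4 is 20000 nM, with a range from 7000 nM to 60000 nM.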

Compound 4, concentration for total growth inhibition: 32400 nM
Compound 4: the middle estimate sits 1.6-fold (0.21 log units) below what was measured, within the range that was stated.
By their numbers in this assay, from the lowest: compound 2; then compounds 4, 1 and 3 (each within the scatter of the next).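

On the aromatic carbon para to a large group, methoxy in place of fluoro gives no readable change in this assay, with a 1.7-fold lower number from compound 3 to compound 4 (0.24 log units; within the scatter). The larger effect appears when one methoxy of the 3,4-dimethoxyphenyl group gives way to hydrogen, with a 4.2-fold higher number from compound 2 to compound 4 (0.62 log units; beyond the scatter), while 4-methoxyphenyl and 3,4-dichlorophenyl cannot be told apart, with a 1.1-fold lower number from compound 1 to compound 4 (0.03 log units; within the scatter). Nothing measured here gives a reason for this pattern.

The compounds shown leave open whether the gain seen with compound 2 needs two methoxy groups specifically, or whether another pair of groups, such as two ethoxy groups or two hydroxyl groups, would give the same result. They also leave open whether a group of a different kind, such as an amine or a carboxylic acid, would change the number in place of the fluoro of compound 3.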